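The source may hold more compounds than are shown below. What is called first, only, known or untested is meant among the compounds shown, and "the series" means these compounds.

Working notes on the series, read in an in vitro ADME assay on microsomes from liver (Homo sapiens) for metabolic stability; a lower number here means slower removal, a higher number faster removal of the compound. Among the measured compounds shown here, compound 1 `O=C(COCc1ccncc1)N1CCN(c2ccc(Cl)cc2)CC1` gives 17 mL.min-1.g-1 and compound 2 `O=C(COCc1ccncc1)N1CCN(c2ccc(Cl)cc2F)CC1` gives 38 mL.min-1.g-1, so compound 2 holds the higher of the two numbers so far. Next is compound 3 `Cc1cc(Cl)ccc1N1CCN(C(=O)COCc2ccncc2)CC1`, with the change methyl in place of fluoro on an aromatic carbon, ortho to a large group and meta to a chloro group, turning 4-chloro-2-fluorophenyl into 4-chloro-2-methylphenyl. For the measured compounds named here, one measured step bears on this carbon: a 2.2-fold higher number from compound 1 to compound 2 (0.35 log units; beyond the scatter), a modest one for fluoro in place of hydrogen. Going by the values given here, no measured compound carries methyl there, so the direction is poorly fixed. In this assay, only a small move toward a higher number is expected, probably not beyond the scatter. The expected step is a 1.2-fold higher number from compound 2 to compound 3 (0.07 log units; within the scatter). For compound 3 the estimated value is 45 mL.min-1.g-1, with an expected range of 22 mL.min-1.g-1 to 90 mL.min-1.g-1.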

Compound 3, intrinsic clearance in microsomes: 68 mL.min-1.g-1
Compound 3: middle estimate off by 1.5-fold (0.18 log units), on the low side, and the stated range covers the measured number.
By their numbers in this assay, from the lowest: compound 1; then compounds 2 and 3 (each within the scatter of the next).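

In this assay methyl on this carbon gives a 4.0-fold higher number from compound 1 to compound 3 (0.60 log units; beyond the scatter) and so, like fluoro, stands beyond the scatter from hydrogen. Methyl in place of fluoro gives a 1.8-fold higher number from compound 2 to compound 3 (0.25 log units; within the scatter) and stays within the scatter, so these two groups cannot be told apart here, and the higher number relative to compound 1 is not limited to fluoro. Nothing at hand accounts for these numbers.

As far as these compounds go, whether the same holds for a methoxy, a trifluoromethyl or a larger alkyl group such as isopropyl on this carbon stays open, so the reach of the effect across substituents is undefined. Also open, from the compounds shown here alone, is whether the step from hydrogen to methyl keeps its size when the chloro group gives way to another group, such as a nitrile.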